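Shortening the side chain: isobutyl to isopropyl

This account rests on a few compounds, and the source may have more. Where it says the series, first, only, none or still open, it means among the compounds named here.

Measured so far:
compound 1, `CC(=O)c1ccc(NC(=O)C(C(C)C)N(C(=O)c2ccccc2)S(=O)(=O)c2ccc(C)cc2)cc1`, 15.6%
compound 2, `CC(=O)c1ccc(NC(=O)CN(C(=O)c2ccccc2)S(=O)(=O)c2ccc([N+](=O)[O-])cc2)cc1`, 20.6%
compound 3, `CC(=O)c1ccc(NC(=O)C(CC(C)C)N(C(=O)c2ccccc2)S(=O)(=O)c2ccc([N+](=O)[O-])cc2)cc1`, 45%

Three compounds share one core and were tested in a functional assay for inhibition, read by spectrophotometry, with a stated time of 20 min, tested at 1 mg/mL; on this read-out higher numbers stand for a stronger effect at the one concentration tested and lower numbers for a weaker effect. Compound 3 gives 45%, the highest of the three numbers, beyond the scatter above both compound 2 and compound 1. Among the measured compounds shown here, the only single-place step among them runs a number 24.4 percentage points higher from compound 2 to compound 3 (beyond the scatter), and that is the step that bears on the new compound.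

Compound 4, `CC(=O)c1ccc(NC(=O)C(C(C)C)N(C(=O)c2ccccc2)S(=O)(=O)c2ccc([N+](=O)[O-])cc2)cc1`, is not yet measured. It differs from compound 3 in one place: isopropyl in place of isobutyl on a saturated chain carbon bound to an amide-type nitrogen and a carbonyl carbon. Isopropyl is shorter than isobutyl by the count given, and longer than the hydrogen of compound 2, so a number between those of compound 2 and compound 3 is expected. Compound 1 also carries isopropyl but differs from compound 3 in a second place too, so its low value is only a loose hint.

Compound 4 is therefore expected to fall by a number 13 percentage points lower from compound 3 to compound 4 (beyond the scatter) in this assay. The estimate for compound 4 is 32%, with a range from 16% to 46%.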

Compound 4, a percentage reported as inhibition, at one concentration (the size of the read-out at that concentration, not a potency): 29.8%
Estimate against measurement, compound 4: 2.2 percentage points above, and the stated range covers the measured number.
By their numbers in this assay, from the lowest: compounds 1, 2 and 4 (each within the scatter of the next, the first and the last beyond it); then compound 3.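

In (this assay), what matters at this saturated chain carbon is the exact side chain, not just the presence of one: isopropyl in place of isobutyl gives (a number 15.2 percentage points lower from compound 3 to compound 4 (beyond the scatter)), while isopropyl in place of hydrogen gives (a number 9.2 percentage points higher from compound 2 to compound 4 (within the scatter)). Among the groups shown, then, only isobutyl stands clear of hydrogen here, and isopropyl cannot be told apart from it. A second place can now also be read with isopropyl held constant, as nitro in place of methyl on an aromatic carbon gives (a number 14.2 percentage points higher from compound 1 to compound 4 (beyond the scatter)), so isopropyl alone does not set the low number of compound 1.

No measurement at hand explains why the extra carbon of isobutyl counts for so much.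

Going by these compounds, whether a longer chain such as n-pentyl, or a chain ending in an amine or a carboxylic acid, would go beyond compound 3 remains open. So does whether nitro in place of methyl gives a similar step when isobutyl occupies the chain carbon.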